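Swapping propanoyl for hydrogen on compound 2

The compounds below may be only part of what the source reports. "The series", "measured", "known", "first", "only" and "open" are said of these compounds alone.

In a functional assay on the whole organism (strain Wistar) with Rattus norvegicus as the target, read by paw edema (a higher number here means that more compound is needed for the effect, a lower number that less compound is needed), compound 1 `CCC(=O)NS(=O)(=O)c1ccc(-n2nc(C(F)(F)F)cc2-c2ccc(Br)cc2)cc1CO` gives 7.2 mg/kg. Compound 2 `CCC(=O)NS(=O)(=O)c1ccc(-n2nc(C(F)(F)F)cc2-c2ccc3c(c2)CCC3)cc1COC(=O)CC` gives 64 mg/kg, the higher of the two numbers, and the gap between them lies beyond the usual scatter. Of these two compounds, compound 2 therefore needs more material for the same effect. Compound 3 `CCC(=O)NS(=O)(=O)c1ccc(-n2nc(C(F)(F)F)cc2-c2ccc3c(c2)CCC3)cc1CO` comes from compound 2 by putting hydrogen in place of propanoyl on an oxygen on a saturated carbon, so that (propanoyloxy)methyl becomes hydroxymethyl. For the measured compounds named here, no measured pair isolates this change, so any forecast is loose. Going by the values given here, the only guide is that compound 1 already carries hydroxymethyl and reads 7.2 mg/kg. A move toward a lower number therefore seems more likely than no move at all. The expected step is a 3.2-fold lower number from compound 2 to compound 3 (0.51 log units; beyond the scatter). For compound 3 the estimated value is 20 mg/kg, with an expected range from 6 mg/kg to 60 mg/kg.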

Compound 3, dose for half-maximal effect: 52 mg/kg
Estimate against measurement, compound 3: 2.6-fold (0.41 log units) below, within the range that was stated.
By their numbers in this assay, from the lowest: compound 1; then compounds 3 and 2 (each within the scatter of the next).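

In this assay, hydrogen in place of propanoyl on this oxygen gives a 1.2-fold lower number from compound 2 to compound 3 (0.09 log units; within the scatter), so with 2,3-dihydro-1H-inden-5-yl present, (propanoyloxy)methyl and hydroxymethyl cannot be told apart at this position. The clear step lies at the other place: 2,3-dihydro-1H-inden-5-yl in place of 4-bromophenyl on an aromatic carbon gives a 7.2-fold higher number from compound 1 to compound 3 (0.86 log units; beyond the scatter) when hydroxymethyl is kept constant. Nothing shown here gives a reason for either step.

As far as these compounds go, whether propanoyl and hydrogen on this oxygen would also read alike with 4-bromophenyl in the molecule remains open. So does the effect of other groups at this position, such as an amine in place of hydroxy or a longer chain such as hexanoyl in place of propanoyl.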